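The source may report more compounds than this note shows. Statements on the series, on what has been measured and on what is new or still open speak of the compounds shown alone.

Of the compounds shown here, two sharing a core have been tested in an ADME assay on HEK-293T cells (Homo sapiens) for cytotoxicity, read by MTT assay, with a stated time of 48 h; a lower number here means that less compound is tolerated, a higher number that more compound is tolerated. Compound 1 `Cn1cc(C2CC(c3ccccc3)=NN2C(=O)c2ccncc2)c2ccccc21` gives 97300 nM. Compound 2 `Cn1cc(C2CC(c3ccc(F)cc3)=NN2C(=O)c2cccnc2)c2cc(Br)ccc21` gives > 300000 nM, and this reading is a limit of the assay, not a number. For the measured compounds named here, no two measured compounds differ in only one place, so no measured step can guide the next prediction.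

Compound 3 `COc1ccc(C2=NN(C(=O)c3cccnc3)C(c3cn(C)c4ccc(Br)cc34)C2)cc1` keeps compound 2 intact apart from one group: it has methoxy in place of fluoro on an aromatic carbon, para to a large group (methoxy in place of fluoro on an aromatic carbon). In other words, 4-fluorophenyl becomes 4-methoxyphenyl.

With only a limit as the starting point, the size of this change is uncertain. A modest move toward less compound being tolerated is expected, possibly no larger than the usual scatter, and the estimate is a step of an at least 1.5-fold lower number from compound 2 to compound 3 (0.17 log units; that floor lies within the scatter). Going by the values given here, the only true number nearby, compound 1 at 97300 nM, guides the expected lower end. The estimate for compound 3 is 200000 nM, with an expected range from 80000 nM to 500000 nM.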

Compound 3, half-maximal cytotoxic concentration: > 300000 nM
Compound 3 gave a limit, no number; the forecaster's own chance of this, stated with the estimate: 40%; middle value at least 1.5-fold (0.17 log units) from the limit.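

Compound 3 gives only a limit of the assay, as compound 2 does, so no step can be read between compound 2 and compound 3, because both stop at the same reading: the limit of > 300000 nM in this assay, at which 2 of the 3 values shown sit. The compounds shown leave open whether 4-methoxyphenyl in place of 4-fluorophenyl changes how much compound the cells tolerate, and in which direction.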